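Bromo for Methyl: Expected Half-Life of Compound 4

A few compounds are considered here, and "the series" means these few. Any claim that something is new, unique, unknown or untested is made for them only; others in the source may bear on it.

Of the compounds shown here, three built on one shared core have been measured in an ADME assay on the whole organism (strain Sprague-Dawley) for metabolic stability, with Rattus norvegicus as the target, at a dose of 5 mg/kg by the oral route; on this read-out higher numbers stand for a longer-lived compound and lower numbers for a shorter-lived compound. Compound 1 `CC(C)c1ccc2c(Nc3cc(C(=O)N[C@@H](C)c4ccccc4)ccc3Sc3ccc(N)cc3)ncnc2n1` gives 2.7 h. Compound 2 `CC(C)c1ccc2c(Nc3cc(C(=O)N[C@@](C)(CO)c4ccccc4)ccc3Sc3ccc(N)cc3)ncnc2n1` gives 2.7 h. Compound 3 `Cc1ccc([C@H](C)NC(=O)c2ccc(Sc3ccc(N)cc3)c(Nc3ncnc4nc(C(C)C)ccc34)c2)cc1` gives 2.6 h. The differences among them are small: no change at the digits printed from compound 1 to compound 2 (within the scatter), a 1.0-fold lower number from compound 1 to compound 3 (0.02 log units; within the scatter) and a 1.0-fold lower number from compound 2 to compound 3 (0.02 log units; within the scatter). Compound 3 therefore stands alongside compound 1 and compound 2 at a level that the scatter does not separate; none of the three can be set apart from the others.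

Compound 4 `CC(C)c1ccc2c(Nc3cc(C(=O)N[C@@H](C)c4ccc(Br)cc4)ccc3Sc3ccc(N)cc3)ncnc2n1` is the next member. Relative to compound 3 the change is bromo in place of methyl on an aromatic carbon. Among the compounds with values here, only one measured step touches that ring: the step from compound 1 to compound 3, which put methyl on it and stayed within the scatter. Within the data shown here, no measured step involves bromo on any ring, so there is no direct precedent; the closest evidence is that changes on this ring, and a change elsewhere on the amide-bearing carbon, left this assay unmoved. Compound 4 is therefore expected to give 2.6 h, within a range from 1.5 h to 4.5 h. The expected step of no change at the digits printed from compound 3 to compound 4 (within the scatter) is estimated to stay within the scatter.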

Compound 4, half-life: 2 h
The estimate for compound 4 lay 1.3-fold (0.11 log units) above the measured number; measured number inside the range.
By their numbers in this assay, from the lowest: compounds 4, 3, 1 and 2 (each within the scatter of the next).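

Bromo on the aromatic carbon para to a large group brings in the first atom at this place that is neither carbon nor hydrogen, and in this assay its swap for methyl gives a modest step (a 1.3-fold lower number from compound 3 to compound 4 (0.11 log units; within the scatter)), while set against plain hydrogen it gives a similar one (a 1.4-fold lower number from compound 1 to compound 4 (0.13 log units; within the scatter)). Set against the compound carrying the 1-(hydroxymethyl)-1-phenylethyl group on the amide nitrogen, the 1-(4-bromophenyl)ethyl group gives another step of similar size (a 1.4-fold lower number from compound 2 to compound 4 (0.13 log units; within the scatter)), so all three new steps stay inside the scatter, and this place has now carried hydrogen, methyl and bromo without the half-life separating them. No supporting data are at hand to say why the half-life holds at this place.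

The compounds shown leave open whether an amine, a carboxylic acid or a longer chain such as butyl at this same ring carbon would also stay inside the scatter. They also leave open whether bromo would give the same picture on the compound that carries the hydroxymethyl group on its amide-bearing carbon.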